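The source may report more compounds than this note shows. Statements on the series, on what has been measured and on what is new or still open speak of the compounds shown alone.

Compound 1, `O=C(NC(=S)NNc1ncnc2ccccc12)c1ccc(Cl)cc1`, is the starting point. In a functional assay on CNE-2 cells (Homo sapiens) for cytotoxicity, read by MTT assay, with a stated time of 72 h (on this read-out lower numbers stand for stronger inhibition and higher numbers for weaker inhibition), compound 1 gives 1530 nM. Compound 2, `Cc1ccc(C(=O)NC(=S)NNc2ncnc3ccccc23)cc1`, differs from compound 1 by methyl in place of chloro on an aromatic carbon, and in this assay compound 2 gives 17200 nM, a step of an 11-fold higher number from compound 1 to compound 2 (1.05 log units; beyond the scatter). Compound 3, `O=C(NC(=S)NNc1ncnc2ccccc12)c1ccccc1Cl`, has the same atoms as compound 1 joined differently, the difference being (2-chlorophenyl in place of 4-chlorophenyl on a carbonyl carbon). In this assay compound 3 gives 6090 nM; the step is a 4.0-fold higher number from compound 1 to compound 3 (0.60 log units; beyond the scatter), and set against compound 2 the step is a 2.8-fold lower number from compound 2 to compound 3 (0.45 log units; beyond the scatter).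

Compound 4, `Cc1ccccc1C(=O)NC(=S)NNc1ncnc2ccccc12`, is not yet measured. It differs from compound 3 by methyl in place of chloro on an aromatic carbon. This is the same kind of change as that from compound 1 to compound 2, but the place is not identical: in the earlier pair the methyl stands para to a large group, here it stands ortho to a large group. Resting on the step of an 11-fold higher number from compound 1 to compound 2 (1.05 log units; beyond the scatter) seen between compound 1 and compound 2, a weakening is expected for compound 4 as well, though the changed place leaves the size uncertain. The step from compound 3 to compound 4 is expected to be about a 4.1-fold higher number from compound 3 to compound 4 (0.61 log units; beyond the scatter). Compound 4 is estimated to give 25000 nM in this assay, with a likely range from 8000 nM to 80000 nM.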

Compound 4, half-maximal inhibitory concentration: 5460 nM
Beside the measured number, compound 4's estimate is 4.6-fold (0.66 log units) above it, outside the stated range (below it).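

Swapping chloro for methyl does not carry over from the 4-substituted phenyl compounds to the 2-substituted ones in this assay: the same change on two cores in this assay, an 11-fold higher number (1.05 log units; beyond the scatter) from compound 1 to compound 2 and a 1.1-fold lower number (0.05 log units; within the scatter) from compound 3 to compound 4, 13-fold (1.10 log units) apart, beyond the scatter of two such steps On the 2-substituted ring, the swap leaves nothing that can be read as a real difference, with a 1.1-fold lower number from compound 3 to compound 4 (0.05 log units; within the scatter), while the change of place still counts, as shown by a 3.2-fold lower number from compound 2 to compound 4 (0.50 log units; beyond the scatter) and, with both the group and its place changed, by a 3.6-fold higher number from compound 1 to compound 4 (0.55 log units; beyond the scatter). Within the data shown here, this warns against reading a step measured at one place as a rule for another, but with only one pair at each place it neither explains the mismatch nor shows how the swap would behave on any further core.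

The compounds shown leave open whether chloro and methyl would also match on the 2-substituted ring if each were replaced by a different group, such as a methoxy group or an amine. Among these compounds, they also leave open how either of those groups would compare with the 4-chlorophenyl of compound 1, the lowest number so far at 1530 nM.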